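Adding a second chloro to compound 1

A few compounds are considered here, and "the series" means these few. Any claim that something is new, unique, unknown or untested is made for them only; others in the source may bear on it.

The series shares one core, with the aryl groups and the substituent on the core varying. In a functional assay on HL-60 cells (Homo sapiens) for inhibition, read by MTT assay, with a stated time of 72 h (on this read-out higher numbers stand for weaker inhibition and lower numbers for stronger inhibition), compound 1 (`Cc1nc(-c2ccccc2)c(C(=O)N2CCN(c3cccc(Cl)c3)CC2)o1`) gives 39.2 nM. Within the data shown here, this is the only number available, so it cannot be ranked against a measured spread. Compound 2 (`CCc1nc(-c2ccc(C(C)(C)C)cc2)c(C(=O)N2CCN(c3cccc(OC)c3)CC2)o1`) is reported as "not active" (no number reported). Compound 1 and compound 3 (`COc1ccc(-c2nc(C)oc2C(=O)N2CCN(c3cccc(Cl)c3)CC2)cc1OC`) share the 3-chlorophenyl group, and compound 3 is reported as "not active" (no number reported). Among the measured compounds shown here, neither entry gives a number, and no two measured compounds differ in one place only, so no measured step is available as a guide.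

Compound 4 (`Cc1nc(-c2ccccc2)c(C(=O)N2CCN(c3cccc(Cl)c3Cl)CC2)o1`) departs from compound 1 by a single change: chloro in place of hydrogen on an aromatic carbon. Chloro replaces hydrogen on an aromatic carbon, ortho to a chloro group and ortho to a large group, turning 3-chlorophenyl into 2,3-dichlorophenyl.

The starting point for the expectation is compound 1 at 39.2 nM. A modest shift toward weaker inhibition in this assay is expected, though a result with no number cannot be excluded. The expected change is a 1.5-fold higher number from compound 1 to compound 4 (0.18 log units; within the scatter), and it may not exceed the usual scatter by much. For compound 4 the estimated value is 60 nM, with an expected range from 12 nM to 300 nM.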

Compound 4, half-maximal inhibitory concentration: 133 nM
Compound 4: middle estimate off by 2.2-fold (0.35 log units), on the low side; the range from low to high includes it.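

In this assay, among these compounds, the step of a 3.4-fold higher number from compound 1 to compound 4 (0.53 log units; beyond the scatter) is the first measured change in one place, and it gives the position ortho to a chloro group and ortho to a large group a direction: going from 3-chlorophenyl to 2,3-dichlorophenyl weakens inhibition by more than the usual scatter. The loss is partial, since compound 4 still gives a number, 133 nM, so chloro at this position leaves inhibition measurable on this read-out. Nothing available accounts for the size or the direction of this step.

Still open, as far as these compounds go, is whether the step belongs to chloro itself or to any group at this position, a question that fluoro, methyl, methoxy or a dimethylamino group there would address. Also open, from the compounds shown here alone, is how much of the step depends on the chloro group already present, which a 2-chlorophenyl counterpart on the shared core would show, and whether the same change carries over to other aryl groups and other substituents on the core.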